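Three measured analogues and an untested third-chlorophenyl variant

A few compounds are considered here, and "the series" means these few. Any claim that something is new, unique, unknown or untested is made for them only; others in the source may bear on it.

Measured so far:
- compound 1, `Nc1scc(CN2CCN(c3ccc(OC(F)(F)F)cc3)CC2)c1C(=O)c1ccc(Cl)cc1` — -51%
- compound 2, `Nc1scc(CN2CCN(c3ccc(F)cc3F)CC2)c1C(=O)c1ccc(Cl)cc1` — -66%
- compound 3, `Nc1scc(CN2CCN(c3ccc(F)c(F)c3)CC2)c1C(=O)c1ccc(Cl)cc1` — -78%

In a functional assay on CHO cells with adenosine receptor A1 (Homo sapiens) as the target, read by cAMP accumulation and immunoassay, with a stated time of 6 min, tested at 1 uM (a lower number here means a stronger effect, a higher number a weaker effect of the compound at the concentration tested), compound 1 gives the highest of the three numbers, and its steps to both other compounds lie beyond the scatter, so it shows the weakest effect of the set. The step of a number 15 percentage points lower from compound 1 to compound 2 (beyond the scatter) and the step of a number 27 percentage points lower from compound 1 to compound 3 (beyond the scatter) both lower the number when a difluorophenyl replaces the 4-(trifluoromethoxy)phenyl on the amine nitrogen in a ring, and a number 12 percentage points lower from compound 2 to compound 3 (beyond the scatter) separates the two difluoro patterns.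

Compound 4, `Nc1scc(CN2CCN(c3cccc(Cl)c3)CC2)c1C(=O)c1ccc(Cl)cc1`, has not yet been measured in this assay. It differs from compound 1 by 3-chlorophenyl in place of 4-(trifluoromethoxy)phenyl on an amine nitrogen in a ring. The two measured steps from compound 1 bear on this change, since each swaps the same 4-(trifluoromethoxy)phenyl for a smaller halogenated phenyl and each lowers the number by a modest but clear amount. A single chlorine is a different substituent than a pair of fluorines, so the size is uncertain, but a lowering in the same direction is expected.

Compound 4 is therefore estimated at -64% in this assay, within -84% to -44%, which would mean an expected step of a number 13 percentage points lower from compound 1 to compound 4 (beyond the scatter).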

Compound 4, a percentage reported as activity, at one concentration (the size of the read-out at that concentration, not a potency): -59%
Compound 4: middle estimate off by 5 percentage points, on the low side; low and high end bracket the measured number.
By their numbers in this assay, from the lowest: compound 3; then compounds 2, 4 and 1 (each within the scatter of the next, the first and the last beyond it).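

In this assay, the 3-chlorophenyl group on the amine nitrogen cannot be told apart from the 4-(trifluoromethoxy)phenyl group (a number 8 percentage points lower from compound 1 to compound 4 (within the scatter)) or from the 2,4-difluorophenyl group (a number 7 percentage points higher from compound 2 to compound 4 (within the scatter)). Only the 3,4-difluorophenyl group stands clearly apart from it (a number 19 percentage points higher from compound 3 to compound 4 (beyond the scatter)), so the clear lowering seen so far on leaving 4-(trifluoromethoxy)phenyl holds for the two difluorophenyl groups, while compound 4 goes against it as a general rule for halogenated phenyl groups at this position. No accompanying measurement explains these differences.

The four compounds do not separate the identity of the halogen from the number of halogens, so the 3-fluorophenyl, 4-chlorophenyl and 3,4-dichlorophenyl groups would be the direct tests of what sets the 3,4-difluorophenyl group apart. They also leave open how an unsubstituted phenyl or a pyridyl group on the same amine nitrogen would compare, and whether any of these trends persists when the 4-chlorophenyl on the carbonyl of the shared core is replaced.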